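The source may report more compounds than this note shows. Statements on the series, on what has been measured and on what is new or still open speak of the compounds shown alone.

Measured compounds:
Compound 1, `CCC(C)C1NC(=O)N(C2CCCCC2)C1=O`: in a functional assay on HeLa cells (Homo sapiens) for inhibition (a lower number here means a stronger inhibitor, a higher number a weaker inhibitor), compound 1 gives > 100000 nM, which is a limit of the assay and not a number.
Compound 2, `CCC(C)C1NC(=O)N(C2CCCC2)C1=O`: in this assay compound 2 gives > 100000 nM, again a limit rather than a number.
Compound 3, `CCC(C)C(NC(=O)NO)C(=O)NCc1ccccc1`: in this assay compound 3 gives > 100000 nM, likewise a limit.

Among the compounds with values here, compound 2 therefore stands where every value so far stands: at the limit of > 100000 nM in this assay, at which 3 of the 3 values shown sit. Within the data shown here, no measured pair differs in one place, so no step between measured compounds can be read off, and nothing separates any compound from another.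

Compound 4, `CC(C)C1NC(=O)N(C2CCCC2)C1=O`, differs from compound 2 by hydrogen in place of methyl on a saturated chain carbon, two bonds along the chain from a saturated ring carbon, which reads as sec-butyl to isopropyl. With three limits and no resolved number anywhere in the series, no step beyond the scatter is expected in this assay in either direction; the expected step is a step that the limit leaves unreadable from compound 2 to compound 4. For compound 4 the estimate in this assay is 150000 nM, within 30000 nM to 1000000 nM, most likely reported again only as a limit.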

Compound 4, half-maximal inhibitory concentration: > 100000 nM
Compound 4: no number, only a limit; the forecaster's own chance of this, stated with the estimate: 90%; the middle value does not contradict the limit.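

In this assay compound 4 gives > 100000 nM, a limit and not a number. Compound 2 also sits at a limit, so no step can be read between compound 2 and compound 4: the limit of > 100000 nM in this assay, at which 4 of the 4 values shown sit. The compounds shown leave open what sec-butyl to isopropyl does to inhibition.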